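Swapping the Anilide Substituent: Predicting a Third Analogue

This account rests on a few compounds, and the source may have more. Where it says the series, first, only, none or still open, it means among the compounds named here.

Compound 1 `O=C(CSc1nc(Nc2ccccc2)c2ccccc2n1)Nc1cccc(F)c1` gives 12700 nM in a functional assay on MGC-803 cells (Homo sapiens) for inhibition, read by MTT assay, with a stated time of 72 h; a higher number here means a weaker inhibitor, a lower number a stronger inhibitor.
Compound 2 `COc1cccc(NC(=O)CSc2nc(Nc3ccccc3)c3ccccc3n2)c1` gives 10000 nM in this assay.

Compound 2 stands at the lower end of the two numbers shown, but its only neighbour, compound 1, lies within the scatter of it, so the two cannot be told apart. Among the measured compounds shown here, the single measured step, a 1.3-fold lower number from compound 1 to compound 2 (0.10 log units; within the scatter), is itself within the scatter. Compound 3 `O=C(CSc1nc(Nc2ccccc2)c2ccccc2n1)Nc1ccc(F)cc1` differs from compound 2 by 4-fluorophenyl in place of 3-methoxyphenyl on an amide-type nitrogen. For the measured compounds named here, no measured step covers this exact exchange; the one step available altered the same ring and hardly moved this assay, so for compound 3 a shift no larger than the scatter is expected, a 1.2-fold higher number from compound 2 to compound 3 (0.08 log units; within the scatter). Compound 3 is therefore estimated at 12000 nM, between 5000 nM and 30000 nM.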

Compound 3, half-maximal inhibitory concentration: > 50000 nM
Compound 3: no number, only a limit; the forecaster's own chance of this, stated with the estimate: 10%; middle value at least 4.1-fold (0.61 log units) away from the limit.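

The group on the amide-type nitrogen is not indifferent after all: the first change there stayed within the scatter, yet 4-fluorophenyl in place of 3-methoxyphenyl brings an at least 5.0-fold higher number from compound 2 to compound 3 (0.69 log units; beyond the scatter). Where the fluorine sits on the ring also counts, as 4-fluorophenyl in place of 3-fluorophenyl brings an at least 3.9-fold higher number from compound 1 to compound 3 (0.59 log units; beyond the scatter). Compound 3 has only a limit, not a number: the limit of > 50000 nM in this assay, at which 1 of the 3 values shown sits.

From the compounds shown here alone, the true size of both steps stays open. A 4-methoxyphenyl group, or an aminophenyl group, would show whether the 4-position itself or the fluorine drives this drop.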